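Swapping methyl for chloro on an aromatic carbon

The source may hold more compounds than are shown below. What is called first, only, known or untested is meant among the compounds shown, and "the series" means these compounds.

Of the compounds shown here, two built on the same core have been tested in an ADME assay on Vero cells (Chlorocebus sabaeus) for cytotoxicity, read by neutral red uptake, tested at 49 ug/mL; a higher number here means a weaker effect of the compound at the concentration tested, a lower number a stronger effect. Compound 1, `COc1ccc(C2SCC(=O)N2CCN2CCCCC2)cc1`, gives 100% in this assay. Compound 2, `Cc1ccc(C2SCC(=O)N2CCN2CCCCC2)cc1`, gives 100%. The single step between them, methyl in place of methoxy on an aromatic carbon, produced no change at the digits printed from compound 1 to compound 2 (within the scatter), so compound 2 stands level with compound 1 at the digits shown.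

Compound 3, `O=C1CSC(c2ccc(Cl)cc2)N1CCN1CCCCC1`, has not yet been measured in this assay. It differs from compound 2 by chloro in place of methyl on an aromatic carbon. Within the data shown here, the one measured step, from compound 1 to compound 2, also changed a small group on that aromatic carbon and left the read-out unchanged within the scatter, so a step of similar size, meaning none beyond the scatter, is expected in this assay: a number 2 percentage points lower from compound 2 to compound 3 (within the scatter). On that basis compound 3 is estimated at 98%, with a range from 85% to 105%.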

Compound 3, a percentage reported as activity, at one concentration (the size of the read-out at that concentration, not a potency): 84%
Compound 3: the middle estimate sits 14 percentage points above what was measured, and the stated range ends above it.
By their numbers in this assay, from the lowest: compound 3; then compounds 1 and 2 (each within the scatter of the next).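

In this assay this place on the aromatic ring proves sensitive to the group it carries: chloro in place of methyl gives a number 16 percentage points lower from compound 2 to compound 3 (beyond the scatter) and chloro in place of methoxy gives a number 16 percentage points lower from compound 1 to compound 3 (beyond the scatter). A lower number here means a stronger effect, so chloro moves the read-out in a way that the exchange of methoxy for methyl did not, and the shift appears from either starting group. Nothing measured here explains why chloro stands apart from methyl and methoxy.

From the compounds shown here alone, whether this shift is particular to chloro stays open, and fluoro, bromo, trifluoromethyl, an amine or a carboxylic acid at the same place would help to show how far it extends. Also open, going by these compounds, is whether chloro would give a step of this size on a different core.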